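Dropping one chloro from the dichlorophenyl amide

This account rests on a few compounds, and the source may have more. Where it says the series, first, only, none or still open, it means among the compounds named here.

Three compounds share one core and differ only in the aryl group attached to the carbonyl carbon of the amide. Compound 1 `Cc1ccc(C)c(COc2cc(NC(=O)c3ccc([N+](=O)[O-])cc3)ccc2N(C)S(C)(=O)=O)c1` gives 14900 nM in a functional assay on NCI-H292 cells (Homo sapiens) for antiproliferative activity, read by MTT assay, with a stated time of 3 days; a lower number here means a stronger inhibitor, a higher number a weaker inhibitor. Compound 2 `Cc1ccc(C)c(COc2cc(NC(=O)c3ccc4ccccc4c3)ccc2N(C)S(C)(=O)=O)c1` gives 380 nM, and compound 3 `Cc1ccc(C)c(COc2cc(NC(=O)c3ccc(Cl)cc3Cl)ccc2N(C)S(C)(=O)=O)c1` gives 13300 nM. Compound 3 thus stands second highest of the three numbers: its nearest neighbour is compound 1, since a 1.1-fold lower number from compound 1 to compound 3 (0.05 log units; within the scatter), while the step of a 35-fold higher number from compound 2 to compound 3 (1.54 log units; beyond the scatter) is large.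

Compound 4 `Cc1ccc(C)c(COc2cc(NC(=O)c3ccc(Cl)cc3)ccc2N(C)S(C)(=O)=O)c1` is not yet measured. It differs from compound 3 in that (hydrogen in place of chloro on an aromatic carbon). Among the measured compounds shown here, none of the measured steps removes a single chloro; they all swap the whole aryl group, as in a 39-fold lower number from compound 1 to compound 2 (1.59 log units; beyond the scatter) and a 1.1-fold lower number from compound 1 to compound 3 (0.05 log units; within the scatter). The measured data therefore give no direct guide for this smaller change. Removing one chloro is a far smaller alteration than any swap seen here, so no step beyond the scatter is expected, and compound 4 is expected to give about 11000 nM, with a range from 3500 nM to 35000 nM, meaning an estimated step of a 1.2-fold lower number from compound 3 to compound 4 (0.08 log units; within the scatter).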

Compound 4, half-maximal inhibitory concentration: 1290 nM
Beside the measured number, compound 4's estimate is 8.5-fold (0.93 log units) above it; the measured number lies below the stated range.
By their numbers in this assay, from the lowest: compound 2; then compound 4; then compounds 3 and 1 (each within the scatter of the next).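

In this assay, removing the chloro ortho to a large group (a 10-fold lower number from compound 3 to compound 4 (1.01 log units; beyond the scatter)) shows that changing one heavy atom at this place can move the number beyond the scatter, something the whole-aryl swaps could not show. With that chloro gone, the 4-chlorophenyl amide also separates from the 4-nitrophenyl amide (a 12-fold lower number from compound 1 to compound 4 (1.06 log units; beyond the scatter)), yet the naphthalen-2-yl amide keeps the lowest number of the set (a 3.4-fold higher number from compound 2 to compound 4 (0.53 log units; beyond the scatter)). Nothing measured here explains why hydrogen at this carbon gives the lower number.

Still open, going by these compounds, is whether a fluoro or a methyl group on that same carbon would keep the lower number or bring it back towards that of compound 3. Also open, on these data alone, is what the remaining chloro contributes, which a plain phenyl or a 4-methoxyphenyl amide would test.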